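Two cores, one chain extension: an estimate for compound 4

The compounds below may be only part of what the source reports. "The series", "measured", "known", "first", "only" and "open" are said of these compounds alone.

Compound 1 `CC(C)CCc1c(OCCCCCCCC(=O)NO)ccc(CCC(=O)NO)c1O` gives 1730 nM in a functional assay on PC-3 cells (Homo sapiens) for antiproliferative activity, read by sulforhodamine B assay, with a stated time of 48 h; a higher number here means a weaker inhibitor of growth, a lower number a stronger inhibitor of growth. Compound 2 `CC(C)CCc1c(OCCCCC(=O)NO)ccc(CCC(=O)NO)c1O` gives 14400 nM. Compound 3 `CC(C)CCc1c(OCCCCC(=O)NO)ccc2c1OC(=O)CC2` reaches only a limit of this assay, > 30000 nM.

Compounds 1 and 2 share a core and differ by 3-(hydroxycarbamoyl)propyl in place of hydroxycarbamoyl on a saturated chain carbon, four bonds along the chain from an oxygen on an aromatic ring; that change gave an 8.3-fold lower number from compound 2 to compound 1 (0.92 log units; beyond the scatter). Compound 3 carries a different core, and the difference between the two cores is not broken down here. Compound 4 `CC(C)CCc1c(OCCCCCCCC(=O)NO)ccc2c1OC(=O)CC2` differs from compound 3 by 3-(hydroxycarbamoyl)propyl in place of hydroxycarbamoyl on a saturated chain carbon, four bonds along the chain from an oxygen on an aromatic ring, the same change, at the same place.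

As far as these compounds go, because compound 3 sits at the limit (the limit of > 30000 nM in this assay, at which 1 of the 3 values shown sits), its starting point is unknown, so the expected step from compound 3 to compound 4 is an at least 2.0-fold lower number from compound 3 to compound 4 (0.30 log units; that floor lies within the scatter), taken from the earlier step as a guide. Compound 4 is therefore estimated at 15000 nM, with a range from 4000 nM to 60000 nM.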

Compound 4, concentration for 50% growth inhibition: > 30000 nM
Compound 4: a limit, no number; the forecaster's own chance of this, stated with the estimate: 35%; middle value at least 2.0-fold (0.30 log units) away from the limit.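

In this assay compound 4 reaches only a limit (> 30000 nM), not a number. Among the compounds shown here, no step from compound 3 to compound 4 can be read, because compound 3 also sits at a limit: the limit of > 30000 nM in this assay, at which 2 of the 4 values shown sit. As far as these compounds go, whether 3-(hydroxycarbamoyl)propyl in place of hydroxycarbamoyl changes growth inhibition on this core stays open.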